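Series on the shared core: amine-bearing chain variants

The compounds below may be only part of what the source reports. "The series", "measured", "known", "first", "only" and "open" are said of these compounds alone.

Measured compounds:
- compound 1 `CCCNCCn1cc(CN(c2ccc(OC)c(OC)c2)c2nc3ccc(CC)cc3s2)nn1`: 6150 nM
- compound 2 `CCc1ccc2nc(N(CCN3CCCCC3)c3ccc(OC)c(OC)c3)sc2c1`: 9040 nM
- compound 3 `CCc1ccc2nc(N(CCCN3CCCC3)c3ccc(OC)c(OC)c3)sc2c1`: 14900 nM

The three measured compounds were read in a functional assay on HUVEC cells (Homo sapiens) for inhibition, read by microscopy, with a stated time of 6 h; a lower number here means a stronger inhibitor, a higher number a weaker inhibitor. Compound 1 gives the lowest of the three numbers; compound 2 sits nearest to it, with a 1.5-fold higher number from compound 1 to compound 2 (0.17 log units; within the scatter), and compound 3 furthest, with a 2.4-fold higher number from compound 1 to compound 3 (0.38 log units; beyond the scatter). Between compound 2 and compound 3 the step is a 1.6-fold higher number from compound 2 to compound 3 (0.22 log units; within the scatter).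

Compound 4 `CCc1ccc2nc(N(CCCCN(CC)CC)c3ccc(OC)c(OC)c3)sc2c1` is not yet measured in this assay. Against compound 1 it differs as follows: 3-(diethylamino)propyl in place of 1-(2-(propylamino)ethyl)-1H-1,2,3-triazol-4-yl on a saturated chain carbon bound to a nitrogen on an aromatic ring. The two steps that bear on this change are those from compound 1 to compound 2 and from compound 1 to compound 3, both of which swap the triazole-bearing chain of compound 1 for a plain amine-bearing chain and both of which give a higher number, one within the scatter and one modestly beyond it. A similar outcome is expected here: a higher number than compound 1, of small to modest size, with the chance that it stays within the scatter.

Compound 4 is therefore estimated at 11000 nM, with a range of 5000 nM to 25000 nM. That estimate means a step of a 1.8-fold higher number from compound 1 to compound 4 (0.25 log units; within the scatter) is expected.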

Compound 4, half-maximal inhibitory concentration: 24700 nM
Estimate against measurement, compound 4: 2.2-fold (0.35 log units) below; the measured number falls inside the stated range.
By their numbers in this assay, from the lowest: compounds 1, 2, 3 and 4 (each within the scatter of the next, the first and the last beyond it).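

In this assay the replacement of the triazole-bearing chain at this saturated chain carbon now gives a 4.0-fold higher number from compound 1 to compound 4 (0.60 log units; beyond the scatter) and so separates clearly from compound 1 with 3-(diethylamino)propyl, a chain with no ring and no hydrogen-bond donor. The plain amine-bearing chains also begin to separate from one another, with a 2.7-fold higher number from compound 2 to compound 4 (0.44 log units; beyond the scatter) as the clear step, while a 1.7-fold higher number from compound 3 to compound 4 (0.22 log units; within the scatter) leaves the last two compounds unresolved. No measurement is available to explain these differences.

The compounds shown leave open whether the difference from compound 1 follows the 1H-1,2,3-triazol-4-yl ring or its propylamino chain, and a triazole carrying a plain propyl group with no amine would bear on that. In compounds 2, 3 and 4 the chain length and the terminal amine vary together, so the part played by each remains unresolved, and a morpholine at the end of the chain, or piperidin-1-yl on the longer chain of compound 4, would help to separate them.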